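This account rests on a few compounds, and the source may have more. Where it says the series, first, only, none or still open, it means among the compounds named here.

Compounds measured in this study:
compound 1 `COc1cc(-c2cc(/C=C/C(=O)c3ccc(N)cc3)[nH]n2)cc(OC)c1OC`: 90%
compound 2 `COc1ccc(-c2cc(/C=C/C(=O)c3ccc(N)cc3)[nH]n2)cc1OC`: 89%
compound 3 `COc1ccc(-c2cc(/C=C/C(=O)c3ccc(N)cc3)[nH]n2)cc1`: 91%

All three were tested in a functional assay on SK-MEL-28 cells (Homo sapiens) for cytotoxicity, read by sulforhodamine B assay, with a stated time of 48 h, tested at 1 uM; a lower number here means a stronger effect, a higher number a weaker effect of the compound at the concentration tested. Compound 1 stands second highest of the three numbers, yet its value lies within the scatter of both compound 2 and compound 3, so the three cannot be told apart. The two single-place steps, a number 1 percentage points lower from compound 1 to compound 2 (within the scatter) and a number 2 percentage points higher from compound 2 to compound 3 (within the scatter), both put hydrogen in place of methoxy on an aromatic carbon and both stay within the scatter.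

Compound 4 `COc1cc(-c2cc(/C=C/C(=O)c3ccc(F)c(F)c3)[nH]n2)cc(OC)c1OC` has not yet been measured. It differs from compound 1 in 3,4-difluorophenyl in place of 4-aminophenyl on a carbonyl carbon. No measured step touches the group on the carbonyl carbon, so nothing shown bears directly on this change; the only guide is that every change seen so far left the number in this assay unmoved beyond the scatter, and compound 1 itself sits high on the scale. Compound 4 is therefore expected to give an estimated 88%, within a range from 70% to 100%. The step expected from this is a number 2 percentage points lower from compound 1 to compound 4 (within the scatter), which would mean no movement beyond the scatter.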

Compound 4, a percentage reported as activity, at one concentration (the size of the read-out at that concentration, not a potency): 98%
For compound 4 the middle estimate is 10 percentage points below the measured one, and the stated range covers the measured number.
By their numbers in this assay, from the lowest: compounds 2, 1, 3 and 4 (each within the scatter of the next).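

Among these compounds, the group on the carbonyl carbon had not been varied among the earlier compounds, and in this assay putting 3,4-difluorophenyl in place of 4-aminophenyl gives a number 8 percentage points higher from compound 1 to compound 4 (within the scatter). Even this exchange of one whole aromatic group, which swaps the amino nitrogen for two fluorine atoms and leaves no hydrogen-bond donor or acceptor on the group, therefore cannot be told apart from no change at this single concentration. No measurement shown here offers an explanation for this result.

Still open, on these data alone, is whether another group on the carbonyl carbon, such as a pyridine ring or a phenyl ring carrying a carboxylic acid, would move the number beyond the scatter. Because each compound is read at one concentration only, the results also leave open how these compounds would compare at higher concentrations.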